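Solubility Around a Shared Thioether Core

A few compounds are considered here, and "the series" means these few. Any claim that something is new, unique, unknown or untested is made for them only; others in the source may bear on it.

Measured in a physicochemical assay for solubility, using the shake flask method, in phosphate buffer, with a stated time of 24 h, at pH 7.4; a higher number here means a more soluble compound, a lower number a less soluble compound:
Compound 1 `O=c1c2cn(C3COC3)nc2nc(SCc2cccc(F)c2)n1-c1ccccc1`: 5000 nM
Compound 2 `COc1cccc(C(C)Sc2nc3c(cnn3C)c(=O)n2-c2ccccc2)c1`: < 2000 nM
Compound 3 `CC(Sc1nc2c(cnn2C)c(=O)n1-c1ccccc1)c1ccccc1`: 8000 nM

Compound 1 holds the lower of the two numbers, yet compound 3 lies within the usual scatter of it, so the two cannot be ranked. The value of compound 2 is a limit of this assay, not a number: the limit of < 2000 nM in this assay, at which 1 of the 3 values shown sits. Within the data shown here, the single measured step, an at least 4.0-fold higher number from compound 2 to compound 3 (0.60 log units; beyond the scatter), changes a substituent on the aromatic ring, not the sulfur. Compound 4 `CC(Sc1nc2nn(C3COC3)cc2c(=O)n1-c1ccccc1)c1cccnc1` differs from compound 1 at the sulfur: 1-(pyridin-3-yl)ethyl in place of 3-fluorobenzyl on a sulfur. Among the measured compounds shown here, no measured step touches this position, so no direction can be drawn from the data. Compound 4 is therefore expected to stay near compound 1, with a 1.4-fold higher number from compound 1 to compound 4 (0.15 log units; within the scatter). The estimate for compound 4 is 7000 nM, between 2500 nM and 20000 nM.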

Compound 4, solubility: 189000 nM
Compound 4: middle estimate off by 27-fold (1.43 log units), on the low side; measured number outside the range, above it.
By their numbers in this assay, from the lowest: compounds 1 and 3 (each within the scatter of the next); then compound 4. At a limit, below all of these: compound 2.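

In this assay, among these compounds, the group on the sulfur proves able to move the number a long way: 1-(pyridin-3-yl)ethyl in place of 3-fluorobenzyl gives a 38-fold higher number from compound 1 to compound 4 (1.58 log units; beyond the scatter) at this position, where the earlier compounds offered no step. The new group carries a ring with a hetero atom and a hydrogen-bond acceptor, while the group that leaves has neither. Nothing shown here explains why the number rises.

Going by these compounds, the ring nitrogen and the changed carbon chain arrive together, so their separate shares stay open. On these data alone, how an amine, a carboxylic acid or a longer chain on the sulfur would read also stays open.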